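A few compounds are considered here, and "the series" means these few. Any claim that something is new, unique, unknown or untested is made for them only; others in the source may bear on it.

Measured so far:
Compound 1, `CCCCS(=O)(=O)Nc1cc(-c2ccc3ncnc(NCCN(C)C)c3c2)cnc1OC`, 280 nM
Compound 2, `COc1ncc(-c2ccc3ncnc(NCCN(C)C)c3c2)cc1NS(=O)(=O)c1ccc(F)cc1`, 9500 nM

Both numbers come from a functional assay on SK-HEP1 cells (Homo sapiens) for antiproliferative activity, read by sulforhodamine B assay, with a stated time of 72 h; on this read-out lower numbers stand for stronger inhibition and higher numbers for weaker inhibition. Compound 1 holds the lowest of the two numbers; its nearest neighbour is compound 2, and the step of a 34-fold higher number from compound 1 to compound 2 (1.53 log units; beyond the scatter) is large. That step alters only the group on the sulfonyl sulfur and leaves the chain on the nitrogen on the aromatic ring untouched.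

Compound 3, `CCCCS(=O)(=O)Nc1cc(-c2ccc3ncnc(NCCCN(C)C)c3c2)cnc1OC`, has not yet been measured. It differs from compound 1 in one place: (dimethylamino)methyl in place of dimethylamino on a saturated chain carbon, two bonds along the chain from a nitrogen on an aromatic ring. Read from the nitrogen on the aromatic ring, the same change is (2-(dimethylamino)ethyl)amino to (3-(dimethylamino)propyl)amino. Within the data shown here, no measured pair shows this chain change, so the one step on record, a 34-fold higher number from compound 1 to compound 2 (1.53 log units; beyond the scatter), does not bear on it directly; it shows only that this assay can respond strongly to a single change elsewhere. Among the measured compounds shown here, with no direct precedent, compound 3 is expected to land close to compound 1, the step of a 1.3-fold higher number from compound 1 to compound 3 (0.10 log units; within the scatter) being expected to stay within the scatter. Compound 3 is estimated at 350 nM, with a range from 120 nM to 1000 nM.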

Compound 3, half-maximal inhibitory concentration: 860 nM
Estimate against measurement, compound 3: 2.5-fold (0.39 log units) below; the range from low to high includes it.
By their numbers in this assay, from the lowest: compound 1; then compound 3; then compound 2.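

Within this assay, the chain on the nitrogen on the aromatic ring proves to be a position that responds to length: going from (2-(dimethylamino)ethyl)amino to (3-(dimethylamino)propyl)amino gives a real loss (a 3.1-fold higher number from compound 1 to compound 3 (0.49 log units; beyond the scatter)). Among these compounds, until now, the only change on record lay on the sulfonyl sulfur, so this is the first reading at the chain, and its step is modest beside the large one at the sulfur (a 34-fold higher number from compound 1 to compound 2 (1.53 log units; beyond the scatter)). Thus, in this small set, the chain tolerates the change better than the sulfonyl sulfur tolerates 4-fluorophenyl in place of butyl, although the longer chain still costs activity, and nothing available explains that cost.

The compounds shown leave open whether a still longer chain, such as a 4-(dimethylamino)butyl group, would raise the number further, and whether a shorter chain or a ring amine such as morpholine at the chain end would do better than dimethylamino. They also leave open whether the chain change and the change on the sulfonyl sulfur would act independently when combined.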